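The source may report more compounds than this note shows. Statements on the series, on what has been measured and on what is new or still open speak of the compounds shown alone.

Measured so far in an ADME assay on the whole organism for pharmacokinetics, with Rattus norvegicus as the target, with a stated time of 6 h, at a dose of 10 mg/kg by the oral route; on this read-out higher numbers stand for higher exposure at the dose given and lower numbers for lower exposure:
Compound 1 `Cc1cn2c(-c3cn[nH]c3)cnc2c(Nc2cc(Cc3cnccn3)ns2)n1` gives 58.4 ng.h/mL in this assay.
Compound 2 `Cc1cn2c(-c3cn[nH]c3)cnc2c(Nc2cc(Cc3ncccc3C)ns2)n1` gives 644 ng.h/mL in this assay.

Compound 2 stands highest of these two numbers. Among the compounds with values here, the only measured step, an 11-fold higher number from compound 1 to compound 2 (1.04 log units; beyond the scatter), exchanged one whole ring for another. Compound 3 `Cc1cn2c(-c3cn[nH]c3)cnc2c(Nc2cc(Cc3ncccc3F)ns2)n1` differs from compound 2 by fluoro in place of methyl on an aromatic carbon. Within the data shown here, no measured step swaps a single group on that ring, so that earlier step offers little guidance, and the expectation stays close to compound 2 with a wide range. Compound 3 is expected to give 450 ng.h/mL, between 120 ng.h/mL and 1500 ng.h/mL, an estimated step of a 1.4-fold lower number from compound 2 to compound 3 (0.16 log units; within the scatter), not beyond the scatter.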

Compound 3, area under the concentration-time curve: 569 ng.h/mL
Beside the measured number, compound 3's estimate is 1.3-fold (0.10 log units) below it; low and high end bracket the measured number.
By their numbers in this assay, from the lowest: compound 1; then compounds 3 and 2 (each within the scatter of the next).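

In this assay, fluoro in place of methyl on the ring gives a 1.1-fold lower number from compound 2 to compound 3 (0.05 log units; within the scatter), so this position accepts either group with no change that stands out from the scatter. The 3-fluoropyridin-2-yl group also gives a 9.7-fold higher number from compound 1 to compound 3 (0.99 log units; beyond the scatter) against pyrazin-2-yl, so the methyl group is not needed for the higher exposure seen with compound 2. Nothing measured here explains these numbers. Still open, on these data alone, is whether a chloro, methoxy or nitrile group at this position would fit the same picture. Also open, as far as these compounds go, is what a pyridin-2-yl ring carrying no group there would give.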